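Cyclohexyl in place of 2-fluorobenzyl on the amide nitrogen

The source may hold more compounds than are shown below. What is called first, only, known or untested is meant among the compounds shown, and "the series" means these compounds.

Compound 1, `C=CC1=C(C(=O)NCc2ccccc2F)C(c2ccc(F)cc2)OC1`, in a functional assay on SW480 cells (Homo sapiens) for cytotoxicity, read by MTT assay, with a stated time of 24 h (a higher number here means a weaker inhibitor, a lower number a stronger inhibitor), gives > 100000 nM, which is a limit of the assay and not a number.
Compound 2, `C=CC1=C(C(=O)Nc2ccc(OCC)cc2)C(c2ccc(OC)cc2)OC1`, in this assay gives > 100000 nM, again a limit of the assay.
Compound 3, `C=CC1=C(C(=O)NCc2ccc(Cl)cc2)C(c2ccc(OC)cc2)OC1`, in this assay gives > 100000 nM, also a limit of the assay.

Compound 1 therefore stands at the ceiling of what this assay reports, and it shares that position with the two other measured compounds, since the limit of > 100000 nM in this assay, at which 3 of the 3 values shown sit, describes every value shown. Going by the values given here, the only pair that differs in a single place is compound 2 and compound 3, and the step between them, a step that the two limits leave unreadable from compound 2 to compound 3, cannot be sized, because both ends are limits. Among the compounds with values here, no measured step is therefore readable.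

Compound 4, `C=CC1=C(C(=O)NC2CCCCC2)C(c2ccc(F)cc2)OC1`, differs from compound 1 by cyclohexyl in place of 2-fluorobenzyl on an amide-type nitrogen. Within the data shown here, with no measured step to lean on, and with every measured value sitting at the limit, the expectation for compound 4 is that this assay will once more return a limit rather than a number. The estimated step from compound 1 to compound 4 is a step that the limit leaves unreadable from compound 1 to compound 4, meaning no change beyond the scatter. For compound 4 the expected value is 150000 nM, with a range from 40000 nM to 600000 nM.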

Compound 4, half-maximal inhibitory concentration: > 100000 nM
Compound 4: no number, only a limit; the forecaster's own chance of this, stated with the estimate: 85%; the middle value does not contradict the limit.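

Compound 4 gives > 100000 nM in this assay, a limit of the assay and not a number. Compound 1 also stands at a limit, so no step can be read between compound 1 and compound 4, and all the compounds share one position: the limit of > 100000 nM in this assay, at which 4 of the 4 values shown sit.

The compounds shown leave open whether any change on the amide nitrogen alters the result in this assay.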